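Losing the Trifluoromethyl: From Compound 2 to Compound 3

The source may report more compounds than this note shows. Statements on the series, on what has been measured and on what is new or still open speak of the compounds shown alone.

Measured in an ADME assay on H9c2 cells (Rattus norvegicus) for cytotoxicity; on this read-out higher numbers stand for weaker inhibition and lower numbers for stronger inhibition:
- Compound 1 `CCc1ccc2nc(NC(=O)C3CC3)sc2c1`: > 50000 nM (a limit)
- Compound 2 `O=C(Nc1nc2ccc(OC(F)(F)F)cc2s1)C1CC1`: 5000 nM

For the measured compounds named here, compound 2, at 5000 nM, holds the only true number so far. Compound 1 gives > 50000 nM, which is a limit of the assay and not a number.

The next compound is compound 3 `CCOc1ccc2nc(NC(=O)C3CC3)sc2c1`. The change is ethyl in place of trifluoromethyl on an oxygen on an aromatic ring, or trifluoromethoxy to ethoxy.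

Going by the values given here, only one measured step bears on this: an at least 10-fold lower number from compound 1 to compound 2 (1.00 log units; beyond the scatter). There, trifluoromethoxy took the place of ethyl on an aromatic carbon. As far as these compounds go, the full size of that step stays open, given (the limit of > 50000 nM in this assay, at which 1 of the 2 values shown sits). Compound 3 also loses trifluoromethoxy, but it keeps the oxygen and gains an ethyl, so it resembles both of its neighbours. A reversal of much of the measured step therefore seems likely, with a higher number in this assay and weaker inhibition, and a reading at the limit is possible.

The expected change is a 5.0-fold higher number from compound 2 to compound 3 (0.70 log units; beyond the scatter). For compound 3 the estimate is 25000 nM, with an expected range of 10000 nM to 50000 nM.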

Compound 3, half-maximal inhibitory concentration: > 50000 nM
Compound 3: a limit, no number; the forecaster's own chance of this, stated with the estimate: 40%; middle value at least 2.0-fold (0.30 log units) away from the limit.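

In this assay, ethyl in place of trifluoromethyl on the oxygen gives an at least 10-fold higher number from compound 2 to compound 3 (1.00 log units; beyond the scatter). The earlier step exchanged the whole trifluoromethoxy for an ethyl on an aromatic carbon, so the oxygen and the trifluoromethyl changed together and could not be told apart; in this new pair the oxygen stays and only the group on it changes, yet the lower number of compound 2 does not remain, so the oxygen alone does not carry that number in these compounds. Compound 3 gives > 50000 nM, which is a limit of the assay and not a number.

As far as these compounds go, compound 1 and compound 3 both stand at a limit, so the step between them cannot be read, and how far the number rises on leaving compound 2 also stays unknown: the limit of > 50000 nM in this assay, at which 2 of the 3 values shown sit. Also open is whether a difluoromethoxy group or a single fluorine atom on the aromatic ring of the shared core would give a number close to that of compound 2 or would also end at the limit.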